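Arylsulfonate series: cyano placement on the sulfonyl aryl ring

The source may report more compounds than this note shows. Statements on the series, on what has been measured and on what is new or still open speak of the compounds shown alone.

Measured compounds in an assay (strain Sprague-Dawley) for inhibition of Amine oxidase [flavin-containing] A (Rattus norvegicus), read by spectrophotometry, with a stated time of 5 min; on this read-out lower numbers stand for stronger inhibition and higher numbers for weaker inhibition:
- compound 1, `CNC(=O)/C=C1/COc2cc(OS(=O)(=O)c3ccccc3)ccc21`: 34 nM
- compound 2, `CNC(=O)/C=C1/COc2cc(OS(=O)(=O)c3cccc(F)c3)ccc21`: 41 nM
- compound 3, `CNC(=O)/C=C1/COc2cc(OS(=O)(=O)c3cccc(C#N)c3)ccc21`: 19 nM

Compound 3 gives the lowest of the three numbers in this assay. Its nearest neighbour is compound 1, and that gap, a 1.8-fold lower number from compound 1 to compound 3 (0.25 log units; within the scatter), lies within the scatter, so compound 3 cannot be set apart from compound 1. The gap to compound 2, a 2.2-fold lower number from compound 2 to compound 3 (0.33 log units; beyond the scatter), is beyond the scatter, though only modestly. The fluoro-for-hydrogen step, a 1.2-fold higher number from compound 1 to compound 2 (0.08 log units; within the scatter), is itself within the scatter.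

Compound 4, `CNC(=O)/C=C1/COc2cc(OS(=O)(=O)c3ccc(C#N)cc3)ccc21`, is not yet measured. It differs from compound 3 in one place: 4-cyanophenyl in place of 3-cyanophenyl on a sulfonyl sulfur. The two compounds hold the same atoms joined differently, so this is a shift of the nitrile within the aryl ring rather than a change of group.

For the measured compounds named here, none of the measured steps is a shift of this kind; they only exchange hydrogen, fluoro and cyano at a fixed place, and the largest of them is modest. Nothing in the data therefore points to a step beyond the scatter in this assay, in either direction; a number near that of compound 3 is expected. For compound 4 the expected value is 25 nM, with a range from 10 nM to 65 nM, which corresponds to an expected step of a 1.3-fold higher number from compound 3 to compound 4 (0.12 log units; within the scatter).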

Compound 4, half-maximal inhibitory concentration: 45 nM
Estimate against measurement, compound 4: 1.8-fold (0.26 log units) below; the measured number falls inside the stated range.
By their numbers in this assay, from the lowest: compounds 3, 1, 2 and 4 (each within the scatter of the next, the first and the last beyond it).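

Shifting the nitrile alone gives a readable change in this assay: a 2.4-fold higher number from compound 3 to compound 4 (0.37 log units; beyond the scatter), the same modest order as the exchange of fluoro for cyano, a 2.2-fold lower number from compound 2 to compound 3 (0.33 log units; beyond the scatter), so where the nitrile sits on the aryl ring carries at least some weight at this sulfonyl position. The 4-cyanophenyl compound cannot be set apart from the unsubstituted phenyl compound, a 1.3-fold higher number from compound 1 to compound 4 (0.12 log units; within the scatter), or from the 3-fluorophenyl compound, a 1.1-fold higher number from compound 2 to compound 4 (0.04 log units; within the scatter), so a nitrile on this ring gives no change beyond the scatter against hydrogen at either of the two places shown, and the readable step exists only between the two nitrile isomers. The data offer no explanation for the difference between the two nitrile placements.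

As far as these compounds go, whether a shift around the ring has a similar effect for other groups, such as a carboxylic acid or an amine, stays open. So does whether any aryl ring is needed on the sulfonyl sulfur at all, as a longer alkyl chain in its place would show.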